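Amide swap in a series sitting at the assay limit

This account rests on a few compounds, and the source may have more. Where it says the series, first, only, none or still open, it means among the compounds named here.

Values in a toxicity assay on THP-1 cells (Homo sapiens) for inhibition (on this read-out higher numbers stand for lower toxicity in this test and lower numbers for higher toxicity in this test), all of them limits:
Compound 1 `COc1ccc(-c2cnc(NC(=O)c3cccc(C#N)c3)n2C)cc1` (> 100000 nM)
Compound 2 `COc1ccc(-c2cnc(NC(=O)c3ccc(F)cc3)n2C)cc1` (>= 50000 nM)
Compound 3 `COc1ccc(-c2cnc(NC(=O)c3ccc(C#N)cc3)n2C)cc1` (> 100000 nM)

Compound 3 stands at a limit (> 100000 nM) and not at a number. Compound 4 `COc1ccc(-c2cnc(NC(=O)c3ccn[nH]3)n2C)cc1` carries 1H-pyrazol-5-yl in place of 4-cyanophenyl on a carbonyl carbon. Two changes at that carbonyl carbon bear on this, a step that the two limits leave unreadable from compound 1 to compound 2 and a step that the two limits leave unreadable from compound 1 to compound 3, and the change a step that the two limits leave unreadable from compound 2 to compound 3 adds no size either. The series sits at the limit of > 100000 nM in this assay, at which 2 of the 3 values shown sit, and at the limit of >= 50000 nM in this assay, at which 1 of the 3 values shown sits, so none of compounds 1 to 3 gives a number. No step beyond the scatter is therefore expected in this assay, and no direction can be assigned. The expected a number no higher from compound 3 to compound 4 (the limit leaves the size open) is accordingly small. Compound 4 is estimated at 100000 nM (expected range 40000 nM to 200000 nM).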

Compound 4, half-maximal cytotoxic concentration: > 100000 nM
Compound 4 ended at the assay's limit (the forecaster's own chance of this, stated with the estimate: 80%); the middle value lies on the limit itself.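

In this assay compound 4 gives > 100000 nM, which is a limit. Going by these compounds alone, no step from compound 1, compound 2 or compound 3 to compound 4 can be read. The compounds shown leave open whether the groups on the carbonyl carbon differ at all in this assay.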